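This account rests on a few compounds, and the source may have more. Where it says the series, first, only, none or still open, it means among the compounds named here.

In a functional assay on cells (T-cell, Mus musculus) for inhibition (on this read-out lower numbers stand for stronger inhibition and higher numbers for weaker inhibition), compound 1 `O=C(Nc1ccccc1)Nc1ccc2c(c1)COC2=O` gives 7090 nM, compound 2 `Cc1ccccc1NC(=O)Nc1ccc2c(c1)COC2=O` gives 900 nM and compound 3 `O=C(Nc1ccc(Cl)cc1)Nc1ccc2c(c1)COC2=O` gives 2450 nM; compound 3 thus stands second highest of the three numbers, with compound 2 nearest and compound 1 furthest. The measured steps are a 7.9-fold lower number from compound 1 to compound 2 (0.90 log units; beyond the scatter), a 2.9-fold lower number from compound 1 to compound 3 (0.46 log units; beyond the scatter) and a 2.7-fold higher number from compound 2 to compound 3 (0.43 log units; beyond the scatter), each a change on the aromatic ring attached to the urea nitrogen. Compound 4 `O=C(Nc1ccc2c(c1)COC2=O)NC1CCCCC1` differs from compound 3 by cyclohexyl in place of 4-chlorophenyl on an amide-type nitrogen. Within the data shown here, no measured step exchanges the aromatic ring for a non-aromatic one, so the three steps bear only loosely on this change; all of them were modest, which points to a modest step here as well, with the direction open. The expectation for compound 4 in this assay is 3500 nM, within 900 nM to 14000 nM, an expected step of a 1.4-fold higher number from compound 3 to compound 4 (0.15 log units; within the scatter).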

Compound 4, half-maximal inhibitory concentration: 12700 nM
Beside the measured number, compound 4's estimate is 3.6-fold (0.56 log units) below it; measured number inside the range.
By their numbers in this assay, from the lowest: compound 2; then compound 3; then compounds 1 and 4 (each within the scatter of the next).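

In this assay, among these compounds, cyclohexyl on the amide-type nitrogen gives a 5.2-fold higher number from compound 3 to compound 4 (0.71 log units; beyond the scatter) and a 14-fold higher number from compound 2 to compound 4 (1.15 log units; beyond the scatter), the latter the largest step so far. Against the plain ring, a 1.8-fold higher number from compound 1 to compound 4 (0.25 log units; within the scatter), so exchanging phenyl for cyclohexyl does not separate the two, and only the substituted aromatic rings of compound 2 and compound 3 stand apart from compound 4. No evidence on the cause of these steps is at hand. Open, as far as these compounds go, is how a longer chain or a benzyl group would read on this nitrogen, and whether a methyl group on the cyclohexyl ring would shift the number.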